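A few compounds are considered here, and "the series" means these few. Any claim that something is new, unique, unknown or untested is made for them only; others in the source may bear on it.

Measured compounds:
compound 1, `Cc1ccsc1CN[C@@H]1C[C@H]2C[C@@H]([C@H]1C)C2(C)C`: 10000 nM
compound 2, `C[C@H]1[C@H](NCc2cc(C3CC3)cs2)C[C@H]2C[C@@H]1C2(C)C`: 25000 nM
compound 3, `CCCc1ccsc1CN[C@@H]1C[C@H]2C[C@@H]([C@H]1C)C2(C)C`: 50000 nM

Three compounds sharing the same core were tested in an ADME assay on MDCK cells (Canis lupus familiaris) for cytotoxicity, read by microscopy, with a stated time of 48 h; on this read-out lower numbers stand for higher toxicity in this test and higher numbers for lower toxicity in this test. Compound 3 gives the highest number of the three, so it is the least toxic here; compound 2 sits within the scatter of it, while compound 1 lies well beyond, giving a number clearly lower than that of compound 3.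

Compound 4, `C=Cc1ccsc1CN[C@@H]1C[C@H]2C[C@@H]([C@H]1C)C2(C)C`, is the next compound. It differs from compound 3 at a single point: vinyl in place of propyl on an aromatic carbon.

Among the measured compounds shown here, one measured step bears on this change. The step of a 5.0-fold higher number from compound 1 to compound 3 (0.70 log units; beyond the scatter) shows that building up the chain on this part of the ring raised the number. Compound 4 partly reverses that build-up, because a 5.0-fold higher number from compound 1 to compound 3 (0.70 log units; beyond the scatter) was driven by lengthening the chain, and vinyl lies between hydrogen and propyl. A drop toward compound 1 is therefore expected, but not all the way, so the step of a 2.0-fold lower number from compound 3 to compound 4 (0.30 log units; within the scatter) is estimated. Compound 4 is expected to give about 25000 nM, within a range from 10000 nM to 60000 nM in this assay.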

Compound 4, minimum cytotoxic concentration: 50000 nM
The estimate for compound 4 lay 2.0-fold (0.30 log units) below the measured number; the range from low to high includes it.
By their numbers in this assay, from the lowest: compound 1; then compounds 2, 3 and 4 (each within the scatter of the next).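

In this assay, the change gives no change at the digits printed from compound 3 to compound 4 (within the scatter) with no shift in the number, so at this place on the ring the shorter vinyl group, with its double bond, does as well as the saturated propyl chain. The step of a 5.0-fold higher number from compound 1 to compound 4 (0.70 log units; beyond the scatter) is the same size as a 5.0-fold higher number from compound 1 to compound 3 (0.70 log units; beyond the scatter) on the printed values, so among these compounds both groups stand clear of methyl, while the difference between them does not show in this read-out. Nothing measured here explains why the two groups give the same number.

From the compounds shown here alone, whether ethyl or a chain longer than propyl would keep the number at this level remains open. So does the outcome with a group that brings in other atoms at this carbon, such as an amine or a carboxylic acid.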